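The compounds below may be only part of what the source reports. "The series", "measured", "known", "first", "only" and "open" are said of these compounds alone.

Series notes. Compound 1 `Nc1ccccc1NC(=O)c1ccc(NC(=S)NCc2ccc(Cl)nc2)cc1` shares its core with compound 2 `Nc1ccccc1NC(=O)c1ccc(CNC(=O)c2cc3cnccc3[nH]2)cc1` and compound 3 `Nc1ccccc1NC(=O)c1ccc(Cn2cc(-c3ccc(NC(=O)NCc4cccnc4)cc3)nn2)cc1`. In an assay on isolated protein for inhibition of Nicotinamide phosphoribosyltransferase (Homo sapiens), read by fluorescence, with stated times of 5 min and 15 min (a higher number here means a weaker inhibitor, a lower number a stronger inhibitor), compound 1 returns only a limit, > 2000 nM, and not a number. Compound 2 likewise sits at a limit in this assay, > 2000 nM. Compound 3 gives 18 nM in this assay. Compound 1 thus stands at the limit of > 2000 nM in this assay, at which 2 of the 3 values shown sit, so where it truly lies is not known. Compound 4 `Nc1ccccc1NC(=O)c1ccc(NC(=S)NCc2cncc(F)c2)cc1` differs from compound 1 in one place: 5-fluoropyridin-3-yl in place of 6-chloropyridin-3-yl on a saturated chain carbon bound to an amide-type nitrogen. Within the data shown here, no measured pair in the set shows a change of this kind, so no shift beyond the scatter is expected in this assay. Compound 4 is expected to give 3500 nM in this assay, with a range from 1200 nM to 12000 nM, most probably reported again as a limit. The implied step is expected to be a step that the limit leaves unreadable from compound 1 to compound 4, which should remain within the scatter.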

Compound 4, half-maximal inhibitory concentration: > 2000 nM
Compound 4 gave a limit, no number; the forecaster's own chance of this, stated with the estimate: 70%; the middle value lies beyond the limit too.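

Compound 1 and compound 4 both return only a limit in this assay, so no step between them can be read: the limit of > 2000 nM in this assay, at which 3 of the 4 values shown sit.

As far as these compounds go, whether 5-fluoropyridin-3-yl in place of 6-chloropyridin-3-yl changes inhibition at all remains open, as does where either compound truly lies.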